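This account rests on a few compounds, and the source may have more. Where it says the series, first, only, none or still open, it means among the compounds named here.

Measured compounds:
compound 1 `Cn1ccc2ccc(-c3cc(Nc4ccccc4S(=O)(=O)NCC4CCOCC4)cc4nccnc34)cc21` — 2 ug/mL
compound 2 `CN(C)C(=O)c1ccncc1Nc1cc(-c2ccc3ccn(C)c3c2)c2nccnc2c1` — 175 ug/mL

Of the compounds shown here, two of a shared core have been measured in a physicochemical assay for solubility, read by spectrophotometry, measured as kinetic solubility, at pH 8, tested at 500 uM; a higher number here means a more soluble compound, a lower number a less soluble compound. Compound 1 gives 2 ug/mL in this assay, while compound 2 gives 175 ug/mL, the higher of the two numbers, and the gap between them lies beyond the usual scatter. Going by the values given here, no step between compounds that differ in a single place has been recorded.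

Compound 3 `CC(=O)N1CCC(NC(=O)c2ccncc2Nc2cc(-c3ccc4ccn(C)c4c3)c3nccnc3c2)C1` has not yet been measured. It differs from compound 2 in one place: (1-acetylpyrrolidin-3-yl)amino in place of dimethylamino on a carbonyl carbon. Seen one bond further out, dimethylcarbamoyl becomes (1-acetylpyrrolidin-3-yl)carbamoyl.

With nothing to go on beyond the value of compound 2 in this assay, the step from compound 2 to compound 3 is expected to stay within the scatter, a 1.2-fold lower number from compound 2 to compound 3 (0.07 log units; within the scatter). Compound 3 is therefore estimated at 150 ug/mL, with a range of 50 ug/mL to 260 ug/mL, because compound 2 already gives 175 ug/mL and the change is a small one at the carbonyl.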

Compound 3, solubility: 253 ug/mL
Estimate against measurement, compound 3: 1.7-fold (0.23 log units) below; measured number inside the range.
By their numbers in this assay, from the lowest: compound 1; then compounds 2 and 3 (each within the scatter of the next).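

Going by these compounds alone, putting (1-acetylpyrrolidin-3-yl)amino in place of dimethylamino on the carbonyl carbon gives a 1.4-fold higher number from compound 2 to compound 3 (0.16 log units; within the scatter) in this assay and is the first single-place step recorded for these compounds. At this position, a larger group bringing a five-membered non-aromatic ring, a hydrogen-bond donor and a hydrogen-bond acceptor leaves the number within the scatter of compound 2. No measurement is available that bears on the reason for this result.

The compounds shown leave open how a primary amine, a carboxylic acid or a longer chain would read at this carbonyl carbon. From the compounds shown here alone, the pyrrolidine ring, the acetyl group and the amide hydrogen all enter together here, so their separate contributions also remain open.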